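The compounds below may be only part of what the source reports. "The series", "measured", "known", "first", "only" and "open" are said of these compounds alone.

Measured compounds:
compound 1, `COC(=O)c1ccc(Cc2c(C)c3ccc(OCC(O)CN4CCC(C(N)=O)CC4)cc3oc2=O)cc1`: > 100000 nM
compound 2, `Cc1c(Cc2cccc3ccccc23)c(=O)oc2cc(OCC(O)CN3CCC(C(N)=O)CC3)ccc12`: 42400 nM
Not yet measured: compound 3, `Cc1c(Cc2ccc(-c3ccc(C=O)c(F)c3)cc2)c(=O)oc2cc(OCC(O)CN3CCC(C(N)=O)CC3)ccc12`.

In an ADME assay on A549 cells (Homo sapiens) for cytotoxicity, read by CellTiter-Glo (a higher number here means that more compound is tolerated, a lower number that less compound is tolerated), compound 1 gives > 100000 nM, which is a limit of the assay and not a number. Where compound 1 stands is thus known only as a limit, the one described by the limit of > 100000 nM in this assay, at which 1 of the 2 values shown sits. In this assay compound 2 gives 42400 nM.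

Compound 3 differs from compound 1 by 3-fluoro-4-formylphenyl in place of methoxycarbonyl on an aromatic carbon. Within the data shown here, the one measured step that bears on this is an at least 2.3-fold lower number from compound 1 to compound 2 (0.37 log units; beyond the scatter), where an aromatic ring also replaced the 4-(methoxycarbonyl)phenyl and the number moved off the limit. Adding a further aromatic ring at the same end of compound 1 is therefore expected to give a step of about an at least 1.6-fold lower number from compound 1 to compound 3 (0.22 log units; that floor lies within the scatter), downward, though with compound 1 at a limit the true size is open. Compound 3 is estimated at 60000 nM, with a range from 20000 nM to 150000 nM.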

Compound 3, half-maximal cytotoxic concentration: 62400 nM
The estimate for compound 3 lay 1.0-fold (0.02 log units) below the measured number; measured number inside the range.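

Placing 3-fluoro-4-formylphenyl in place of methoxycarbonyl, on an aromatic carbon para to a large group, gives in this assay an at least 1.6-fold lower number from compound 1 to compound 3 (0.20 log units; that floor lies within the scatter). Compound 3 thus joins compound 2 in giving a number, which shows that a second way of putting more aromatic ring at this end of the molecule also leaves the limit, here with nine heavy atoms entering where four leave. The true size of the step cannot be read, because compound 1 stands at a limit and not at a number: the limit of > 100000 nM in this assay, at which 1 of the 3 values shown sits.

The compounds shown leave open whether the added ring, the fluorine or the formyl group accounts for the step, since all three enter together. They also leave open how a carboxylic acid or an amine in the same place would read in this assay.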